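The compounds below may be only part of what the source reports. "The series", "measured", "known", "first", "only" and "open" are said of these compounds alone.

Measured in a functional assay on NCI-H460 cells (Homo sapiens) for antiproliferative activity, read by MTT assay, with a stated time of 72 h; a lower number here means a stronger inhibitor, a higher number a weaker inhibitor: compound 1 `CNC(=O)c1cc(Oc2ccc(NC(=O)c3cc4cccnc4n(-c4ccc(Br)cc4)c3=O)cc2)ccn1` gives 3710 nM; compound 2 `CCCNC(=O)c1cc(Oc2ccc(NC(=O)c3cc4cccnc4n(-c4ccccc4)c3=O)cc2)ccn1` gives 110 nM; compound 3 `CCCNC(=O)c1cc(Oc2ccc(NC(=O)c3cc4cccnc4n(-c4ccc(F)cc4)c3=O)cc2)ccn1` gives 120 nM.

Compound 3 stands second highest of the three numbers. Compound 2 sits closest, the step of a 1.1-fold higher number from compound 2 to compound 3 (0.04 log units; within the scatter) lying within the scatter, while compound 1 sits far above. Compound 4 `CCCNC(=O)c1cc(Oc2ccc(NC(=O)c3cc4cccnc4n(-c4ccc(Br)cc4)c3=O)cc2)ccn1` carries bromo in place of fluoro on an aromatic carbon. Among the measured compounds shown here, no measured step swaps one halogen for another; the only step touching this group, a 1.1-fold higher number from compound 2 to compound 3 (0.04 log units; within the scatter), shows that introducing fluoro changed little. Compound 1 also bears bromo, but it differs from compound 4 in more than one place, so its value informs compound 4 only loosely. A modest rise in the number is expected, a 1.8-fold higher number from compound 3 to compound 4 (0.26 log units; within the scatter). Compound 4 is therefore estimated at 220 nM, in the range 70 nM to 900 nM.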

Compound 4, half-maximal inhibitory concentration: 620 nM
Compound 4: middle estimate off by 2.8-fold (0.45 log units), on the low side; the range from low to high includes it.
By their numbers in this assay, from the lowest: compounds 2 and 3 (each within the scatter of the next); then compound 4; then compound 1.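

In this assay the halogen on this ring now matters: the change from 4-fluorophenyl to 4-bromophenyl gives a 5.2-fold higher number from compound 3 to compound 4 (0.71 log units; beyond the scatter) and bromo in place of hydrogen gives a 5.6-fold higher number from compound 2 to compound 4 (0.75 log units; beyond the scatter) against the within-scatter fluoro step. With bromo held fixed, ethyl in place of hydrogen on the amide chain gives a 6.0-fold lower number from compound 1 to compound 4 (0.78 log units; beyond the scatter) so the longer chain still counts alongside bromo. No supporting measurement accounts for either effect. Going by these compounds, whether chloro or an amine at this place would sit nearer fluoro or bromo stays open. So does whether a longer chain on the amide would lower the number further.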